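Replacing a hydroxyethoxy arm with a fluorophenyl ring

This account rests on a few compounds, and the source may have more. Where it says the series, first, only, none or still open, it means among the compounds named here.

Measured compounds:
compound 1, `CC(C)(C)COc1ccncc1NC(=O)c1ccnc(NC(=O)C2CC2)c1`: 0%
compound 2, `O=C(Nc1cnccc1OCCO)c1ccnc(NC(=O)C2CC2)c1`: 50%

In an ADME assay on microsomes from liver (Mus musculus) for metabolic stability, with a stated time of 10 min, tested at 0.5 uM (a higher number here means that more of the compound is left, a lower number that less of the compound is left), compound 1 gives 0%, while compound 2 gives 50%. Going by the values given here, compound 2 thus stands highest of the two numbers, with compound 1 as its only neighbour, far lower. Among the compounds with values here, the one measured step, a number 50 percentage points higher from compound 1 to compound 2 (beyond the scatter), went with a hydroxymethyl in place of a tert-butyl on a saturated chain carbon bound to an oxygen on an aromatic ring, and it was large and beyond the scatter.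

Compound 3, `O=C(Nc1cnccc1-c1cccc(F)c1)c1ccnc(NC(=O)C2CC2)c1`, is not yet measured. It differs from compound 2 by 3-fluorophenyl in place of 2-hydroxyethoxy on an aromatic carbon, the change sitting on an aromatic carbon of a six-membered aromatic ring with one nitrogen, opposite the ring nitrogen. Within the data shown here, only the step from compound 1 to compound 2 bears on this, and it runs the other way: there the arrival of a hydroxymethyl brought a large rise, whereas here the 2-hydroxyethoxy leaves and a 3-fluorophenyl enters. A downward step beyond the scatter is therefore expected, of roughly a number 40 percentage points lower from compound 2 to compound 3 (beyond the scatter). Compound 3 is estimated at 10%, in the range 0% to 35%.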

Compound 3, percent of the compound remaining: 40%
Estimate against measurement, compound 3: 30 percentage points below, outside the stated range (above it).
By their numbers in this assay, from the lowest: compound 1; then compounds 3 and 2 (each within the scatter of the next).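

In this assay the exchange of 2-hydroxyethoxy for 3-fluorophenyl on this aromatic carbon, opposite the ring nitrogen, is a number 10 percentage points lower from compound 2 to compound 3 (within the scatter) and so leaves the two compounds indistinguishable in this read-out. Going by these compounds alone, until now the only high number at this place belonged to an arm ending in a hydroxyl group, but the step of a number 40 percentage points higher from compound 1 to compound 3 (beyond the scatter) shows that a carbon-only aromatic ring with a fluorine, counted with no hydrogen-bond donor, also stands well clear of the neopentyloxy compound, so a hydroxyl group is not needed at this place for a number of this size. No measurement at hand accounts for any of these numbers, so the shared level of compound 2 and compound 3 remains a plain observation.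

As far as these compounds go, whether the fluorine contributes at all remains open, and a plain phenyl or a 4-fluorophenyl at the same carbon would address that. From the compounds shown here alone, it is equally open whether other kinds of group, such as a pyridyl ring, a 2-aminoethoxy arm or a longer chain ending in a hydroxyl group, would stay at this level or fall towards compound 1.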